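Adding a Chloro Group to Compound 1

A few compounds are considered here, and "the series" means these few. Any claim that something is new, unique, unknown or untested is made for them only; others in the source may bear on it.

In a functional assay on MDA-MB-231 cells (Homo sapiens) for cytotoxicity, read by MTT assay, with a stated time of 48 h (a higher number here means a weaker inhibitor, a lower number a stronger inhibitor), compound 1 `Cc1[nH]c2ccc([N+](=O)[O-])cc2c1C1(c2c(C)[nH]c3ccc([N+](=O)[O-])cc23)C(=O)Nc2ccccc21` gives 99400 nM. Compound 3 `N#Cc1ccc2[nH]cc(C3(c4c[nH]c5ccc(C#N)cc45)C(=O)Nc4ccccc43)c2c1` gives 99100 nM, and this lies within the usual scatter of repeated measurements, so the two stand level. Compound 2 `O=C1Nc2ccccc2C1(c1c(-c2ccccc2)[nH]c2ccccc12)c1c(-c2ccccc2)[nH]c2ccccc12` shows > 100000 nM, which is a limit of the assay and not a number. Compound 4 `Cc1[nH]c2ccc([N+](=O)[O-])cc2c1C1(c2c(C)[nH]c3ccc([N+](=O)[O-])cc23)C(=O)Nc2ccc(Cl)cc21` keeps the core of compound 1 and carries chloro in place of hydrogen on an aromatic carbon. Within the data shown here, no measured pair here shows what such a swap does, so only a modest move toward a stronger inhibitor is expected, an estimated step of a 1.7-fold lower number from compound 1 to compound 4 (0.22 log units; within the scatter) in this assay. Compound 4 is expected at 60000 nM, with a likely range from 20000 nM to 100000 nM.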

Compound 4, half-maximal inhibitory concentration: 10100 nM
For compound 4 the middle estimate is 5.9-fold (0.77 log units) above the measured one; the whole stated range lies above it.
By their numbers in this assay, from the lowest: compound 4; then compounds 3 and 1 (each within the scatter of the next). At a limit, above all of these: compound 2.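

Chloro in place of hydrogen on this aromatic carbon of the core of compound 1 gives, in this assay, a 9.8-fold lower number from compound 1 to compound 4 (0.99 log units; beyond the scatter). Before this, no measured pair differed in one place, so this position had no reading; now a single chlorine atom here is seen to shift the number beyond the scatter. The data shown give no reason for this step.

As far as these compounds go, whether this step is particular to chloro remains open, since bromo, methoxy or an amine at this position would test that. Also open, from the compounds shown here alone, is whether chloro does the same on the core of compound 3.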